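The source may report more compounds than this note shows. Statements on the series, on what has been measured and on what is new or still open speak of the compounds shown alone.

Measured compounds:
Compound 1, `CCO/C(O)=C1/C(C)=Nc2nccn2C1c1cccc(Cl)c1Cl`, 96 nM
Compound 2, `CC1=Nc2cc(=O)[nH]n2C(c2cccc([N+](=O)[O-])c2)/C1=C(/O)OC(C)C`, 318 nM
Compound 3, `CC1=Nc2cc(=O)n(Cc3ccccc3)n2C(c2cccc([N+](=O)[O-])c2)/C1=C(/O)OC(C)C`, 5 nM

All three were tested in a functional assay (thoracic aorta) with Oryctolagus cuniculus as the target (a lower number here means a stronger inhibitor, a higher number a weaker inhibitor), so a smaller value means the aorta tissue is inhibited by less compound. Compound 3 stands at the lowest of the three values: compound 1 is nearest, with a value a full step higher, and compound 2 is furthest, with a value higher still, both gaps beyond the scatter.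

Compound 4, `CC1=Nc2cc(=O)n(C(=O)c3ccccc3)n2C(c2cccc([N+](=O)[O-])c2)/C1=C(/O)OC(C)C`, has not been measured. It differs from compound 3 in one place: benzoyl in place of benzyl on an aromatic nitrogen.

Within the data shown here, only one measured step touches that same position: a 64-fold lower number from compound 2 to compound 3 (1.80 log units; beyond the scatter). That step shows that putting a group on this nitrogen, rather than leaving hydrogen there, goes with a much lower number. Among the measured compounds shown here, compound 4 keeps an aromatic ring on that nitrogen, so the large gain seen in compound 3 may largely be kept, but the link now carries a carbonyl, and no measured pair shows what that does. The direction is uncertain, leaning toward a somewhat higher number, and the step that is expected is modest: the expected step is a 2.4-fold higher number from compound 3 to compound 4 (0.38 log units; beyond the scatter). Compound 4 is estimated at 12 nM, within the range 3 nM to 50 nM.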

Compound 4, half-maximal inhibitory concentration: 54 nM
For compound 4 the middle estimate is 4.5-fold (0.65 log units) below the measured one; measured number outside the range, above it.
By their numbers in this assay, from the lowest: compound 3; then compounds 4 and 1 (each within the scatter of the next); then compound 2.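

In this assay, benzoyl in place of benzyl on the aromatic nitrogen gives an 11-fold higher number from compound 3 to compound 4 (1.03 log units; beyond the scatter), so at this position the outcome depends on more than an aromatic ring being present: the two groups carry the same kind of ring, and benzoyl adds one oxygen, a double bond outside the ring and a hydrogen-bond acceptor. Benzoyl in place of hydrogen still gives a 5.9-fold lower number from compound 2 to compound 4 (0.77 log units; beyond the scatter), so part of the gain from substituting this nitrogen remains, and the three groups now rank with benzyl lowest, then benzoyl, then hydrogen. No measurement at hand accounts for the gap between benzyl and benzoyl.

The compounds shown leave open whether the aromatic ring is needed at all, since a plain methyl or a longer carbon chain on this nitrogen would test that, and acetyl would show how a carbonyl behaves without the ring. They also leave open how the link itself can vary, for instance whether a phenethyl group, with its longer chain to the ring, would hold the low number of compound 3.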